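A few compounds are considered here, and "the series" means these few. Any claim that something is new, unique, unknown or untested is made for them only; others in the source may bear on it.

Three compounds share one core and differ only in the aromatic group on an aromatic carbon next to the ring sulfur. In a functional assay on FM3A cells (Mus musculus) for antiproliferative activity (a lower number here means a stronger inhibitor, a higher number a weaker inhibitor), compound 1 (`COc1cc(C(=O)c2sc(-c3ccc(I)cc3)cc2N)cc(OC)c1OC`) gives 420 nM, compound 2 (`COc1cc(C(=O)c2sc(-c3ccncc3)cc2N)cc(OC)c1OC`) gives 150 nM, and compound 3 (`COc1cc(C(=O)c2sc(-c3ccccc3Cl)cc2N)cc(OC)c1OC`) gives 34 nM. Compound 3 therefore has the lowest number of the three and is the strongest inhibitor among them. Compound 4 (`COc1cccc(-c2cc(N)c(C(=O)c3cc(OC)c(OC)c(OC)c3)s2)c1`) keeps the core but carries 3-methoxyphenyl in place of 2-chlorophenyl on an aromatic carbon.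

For the measured compounds named here, no measured step makes this exact swap, and no measured compound carries a methoxyphenyl group at this place, so the evidence is indirect. Putting in 2-chlorophenyl gave a 12-fold lower number from compound 1 to compound 3 (1.09 log units; beyond the scatter), a large step, and a 4.4-fold lower number from compound 2 to compound 3 (0.64 log units; beyond the scatter), a modest one. The two weaker compounds also differ from each other, by a 2.8-fold lower number from compound 1 to compound 2 (0.45 log units; beyond the scatter). Changing this group has thus moved the number beyond the scatter in all three comparisons, and leaving 2-chlorophenyl has always raised it. Three compounds cannot establish a rule, but a modest rise in this assay is the reasonable expectation for compound 4. The estimated step is a 2.9-fold higher number from compound 3 to compound 4 (0.47 log units; beyond the scatter). For compound 4 the expected value is 100 nM, with an estimated range from 30 nM to 350 nM.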

Compound 4, half-maximal inhibitory concentration: 36 nM
Estimate against measurement, compound 4: 2.8-fold (0.44 log units) above; the range from low to high includes it.
By their numbers in this assay, from the lowest: compounds 3 and 4 (each within the scatter of the next); then compound 2; then compound 1.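

In this assay, for the compounds shown here, the swap gives a 1.1-fold higher number from compound 3 to compound 4 (0.02 log units; within the scatter) and so shows for the first time that leaving 2-chlorophenyl need not raise the number at this place, next to the ring sulfur. 3-Methoxyphenyl carries no chlorine and brings an oxygen that 2-chlorophenyl lacks, yet the two compounds cannot be told apart here, so in this pair the low number does not depend on that chlorine. The new group also keeps the distance to the two weaker compounds, with a 4.2-fold lower number from compound 2 to compound 4 (0.62 log units; beyond the scatter) as a modest step and a 12-fold lower number from compound 1 to compound 4 (1.07 log units; beyond the scatter) as a large one, so the low numbers are not unique to 2-chlorophenyl.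

The two groups differ both in the atoms attached to the phenyl ring and in where those atoms sit on it, so these compounds cannot separate the two changes, and they leave open what 2-methoxyphenyl, 3-chlorophenyl, or a phenyl ring bearing an amine or a carboxylic acid would give at this place. Nothing in the data shown offers a measured reason for the match between 2-chlorophenyl and 3-methoxyphenyl.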